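Swapping the thiophene for a pyrrole on the enone ketone

The compounds below may be only part of what the source reports. "The series", "measured", "known", "first", "only" and "open" are said of these compounds alone.

Two compounds share a core and differ only in the aryl group attached to the carbonyl carbon. Compound 1, `COc1ccc(-c2cc3ccccc3nc2/C=C/C(=O)c2ccc(F)cc2)cc1`, gives 8320 nM in a functional assay on A549 cells (Homo sapiens) for antiproliferative activity, read by XTT assay, with a stated time of 72 h; a higher number here means a weaker inhibitor, a lower number a stronger inhibitor. Compound 2, `COc1ccc(-c2cc3ccccc3nc2/C=C/C(=O)c2cccs2)cc1`, gives 920 nM in this assay. For the measured compounds named here, the one measured step, a 9.0-fold lower number from compound 1 to compound 2 (0.96 log units; beyond the scatter), shows that the aroyl group can move the read-out clearly beyond the scatter. Compound 2 therefore stands at the lower of the two numbers, with compound 1 clearly higher.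

Compound 3, `COc1ccc(-c2cc3ccccc3nc2/C=C/C(=O)c2ccc[nH]2)cc1`, is not yet measured. Its difference from compound 2 is 1H-pyrrol-2-yl in place of thiophen-2-yl on a carbonyl carbon. Going by the values given here, no measured step bears directly on this exchange of one five-membered ring for another; the step from compound 1 to compound 2 only tells that the aroyl group matters, and it concerns a six-membered ring in place of the thiophene. Without a closer precedent, the expectation for compound 3 is a number near that of compound 2, with a step of a 1.5-fold higher number from compound 2 to compound 3 (0.18 log units; within the scatter) estimated in this assay. Compound 3 is thus estimated at 1400 nM, with a range from 400 nM to 5000 nM.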

Compound 3, half-maximal inhibitory concentration: > 10000 nM
Compound 3 gave a limit, no number (the forecaster's own chance of this, stated with the estimate: 5%); middle value at least 7.1-fold (0.85 log units) away from the limit.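

The reading for compound 3 in this assay is a limit of the assay and not a number: the limit of > 10000 nM in this assay, at which 1 of the 3 values shown sits.

Even so, replacing thiophen-2-yl with 1H-pyrrol-2-yl on the carbonyl carbon gives an at least 10-fold higher number from compound 2 to compound 3 (1.03 log units; beyond the scatter), so this position separates two five-membered aromatic rings that each hold 1 hetero atom and have the same count of heavy atoms; the earlier step, which set a six-membered ring against the thiophene, could not show this. The comparison with the 4-fluorophenyl compound is far less informative, at an at least 1.2-fold higher number from compound 1 to compound 3 (0.07 log units; that floor lies within the scatter), and with that floor inside the scatter it sets no order between those two compounds.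

The compounds shown do not tell whether the gap from the thiophene follows the loss of the ring sulfur or the arrival of the hydrogen on the ring nitrogen, a change that also turns 1 hydrogen-bond acceptor into 1 hydrogen-bond donor in the counts for these groups. Going by these compounds, a furan-2-yl group, with oxygen in the ring, or a 1-methyl-1H-pyrrol-2-yl group, with a methyl on the ring nitrogen in place of that hydrogen, remains untested among them as a way of pulling these two differences apart.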